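Cytotoxicity notes on a chromone acrylamide pair

The compounds below may be only part of what the source reports. "The series", "measured", "known", "first", "only" and "open" are said of these compounds alone.

Measured compounds:
compound 1 `Cc1ccccc1NC(=O)/C=C/c1coc2cc(O)ccc2c1=O` — 374000 nM
compound 2 `COc1ccc2c(=O)c(/C=C/C(=O)Nc3ccccc3C)coc2c1` — 59700 nM

In an ADME assay on HepG2 2.2.15 cells (Homo sapiens) for cytotoxicity, read by MTT assay, with stated times of 48 h and 9 days (on this read-out higher numbers stand for lower toxicity in this test and lower numbers for higher toxicity in this test), compound 1 gives 374000 nM, the highest of the two numbers, so the least toxic in this test. Compound 2 stands nearest, and the step of a 6.3-fold lower number from compound 1 to compound 2 (0.80 log units; beyond the scatter) comes from a methyl in place of hydrogen on an oxygen on an aromatic ring.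

Compound 3 `COc1ccc(NC(=O)/C=C/c2coc3cc(O)ccc3c2=O)cc1` is not yet measured. It differs from compound 1 by 4-methoxyphenyl in place of 2-methylphenyl on an amide-type nitrogen. Among the measured compounds shown here, the only measured step concerns the phenol oxygen of the shared core, not the group on the amide-type nitrogen, so nothing measured bears directly on this change. A step no larger than the scatter is therefore expected, with the number of compound 3 estimated close to that of compound 1, the step of a 1.5-fold lower number from compound 1 to compound 3 (0.17 log units; within the scatter) expected to be small. Compound 3 is estimated at 250000 nM, within 80000 nM to 600000 nM.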

Compound 3, half-maximal cytotoxic concentration: 976000 nM
Compound 3: the middle estimate sits 3.9-fold (0.59 log units) below what was measured, and the stated range ends below it.
By their numbers in this assay, from the lowest: compound 2; then compound 1; then compound 3.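

In this assay, the group on the amide-type nitrogen does affect the read-out: 4-methoxyphenyl in place of 2-methylphenyl gives a 2.6-fold higher number from compound 1 to compound 3 (0.42 log units; beyond the scatter) and so points toward lower toxicity in this test. The earlier pair showed a change only at the phenol oxygen of the shared core, and in the opposite direction, with a 6.3-fold lower number from compound 1 to compound 2 (0.80 log units; beyond the scatter) as the number fell. This second site therefore also moves the number, though no measurement given here explains why.

Among the compounds shown here, the single swap changes the group on the ring and its place together, so it cannot show whether the methoxy group or the loss of the methyl group carries the step. On these data alone, a plain phenyl group, or a carboxylic acid or an amine on this ring, would test how far this position tolerates change, and whether the step holds with a methyl group on the phenol oxygen also remains open.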